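Removing an Amide Side Chain from a Cyclopropyl Aryl Ether

A few compounds are considered here, and "the series" means these few. Any claim that something is new, unique, unknown or untested is made for them only; others in the source may bear on it.

Compound 1 `C[C@H](Oc1ccc2ncc(/C=C/c3nn[nH]n3)c(C3CC3)c2c1)c1c(Cl)cccc1Cl`: 4.3
Compound 2 `C[C@H](Oc1cc(CO)c2ncc(/C=C/C(=O)O)c(C3CC3)c2c1)c1c(Cl)ccc(F)c1Cl`: 2.9
Compound 3 `C[C@H](Oc1ccc(NC(=O)CC(N)=O)c(C2CC2)c1)c1c(Cl)ccc(F)c1Cl`: 3.9

In a physicochemical assay for lipophilicity, using the shake flask method (on this read-out higher numbers stand for higher lipophilicity and lower numbers for lower lipophilicity), compound 3 gives 3.9, the second highest of the three numbers: compound 1 lies higher by a margin beyond the scatter, and compound 2 lies lower by a larger margin, also beyond the scatter. Compound 4 `C[C@H](Oc1cccc(C2CC2)c1)c1c(Cl)ccc(F)c1Cl` has not yet been measured. It differs from compound 3 in one place: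

hydrogen in place of ((carbamoylmethyl)carbonyl)amino on an aromatic carbon

Among the compounds with values here, no step between two measured compounds differing in a single place is available, so the expectation rests on the change alone. The leaving group carries hydrogen-bond donors and acceptors, and its replacement by hydrogen is expected to raise the value by a step beyond the scatter. Compound 4 is therefore estimated at 4.9, within 4.3 to 5.5. That estimate means an upward step of a number 1.00 log units higher from compound 3 to compound 4 (beyond the scatter).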

Compound 4, distribution coefficient: 5
For compound 4 the middle estimate is 0.10 log units below the measured one; the range from low to high includes it.
By their numbers in this assay, from the lowest: compound 2; then compound 3; then compound 1; then compound 4.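

In this assay, within the data shown here, the change of hydrogen in place of ((carbamoylmethyl)carbonyl)amino gives a number 1.10 log units higher from compound 3 to compound 4 (beyond the scatter), the first step here between compounds that differ in one place. It shows that, on this aromatic carbon ortho to a cyclopropyl group, the loss of this side chain goes with a large rise in the read-out. Nothing measured here accounts for the size of that step.

From the compounds shown here alone, whether a plain amine or a shorter acetylamino chain on this carbon would keep part of the step remains open. So does the outcome for a carboxylic acid there.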